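This account rests on a few compounds, and the source may have more. Where it says the series, first, only, none or still open, it means among the compounds named here.

Measured compounds in an ADME assay on Akata cells (Homo sapiens) for cytotoxicity, with a stated time of 7 days; a lower number here means that less compound is tolerated, a higher number that more compound is tolerated:

compound 1, `CCCCSc1nc(N)nc2c1ncn2/C=C1/CC1(CO)CO`: > 20000 nM, a limit of the assay
compound 2, `CCCCNc1nc(N)nc2c1ncn2/C=C1/CC1(CO)CO`: > 24000 nM, a limit of the assay
compound 3, `CCCSc1nc(N)nc2c1ncn2/C=C1/CC1(CO)CO`: > 20000 nM, a limit of the assay

None of the three values is a number; each is a limit. Compound 3 stands at the limit of > 20000 nM in this assay, at which 2 of the 3 values shown sit. Compound 2 stands at the limit of > 24000 nM in this assay, at which 1 of the 3 values shown sits. Compound 1 shares the lower of the two limits. Every value is a limit. None of the steps among the measured compounds can be sized: a step that the two limits leave unreadable from compound 1 to compound 2; a step that the two limits leave unreadable from compound 1 to compound 3; a step that the two limits leave unreadable from compound 2 to compound 3.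

Compound 4, `Nc1nc(OCC(F)(F)F)c2ncn(/C=C3/CC3(CO)CO)c2n1`, is the next compound, and it differs from compound 3 as follows: 2,2,2-trifluoroethoxy in place of propylsulfanyl on an aromatic carbon

Within the data shown here, the steps that bear on this change are the two that end at compound 3, from compound 1 and from compound 2, and both leave their size unreadable. Nothing in the measured set therefore gives a direction or a size for the change in this assay. The expectation is that compound 4 behaves like the others and that the assay again reports a limit rather than a number, so the estimated step is a step that the limit leaves unreadable from compound 3 to compound 4, none beyond the scatter. Compound 4 is estimated at 25000 nM, with a range from 10000 nM to 60000 nM.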

Compound 4, half-maximal cytotoxic concentration: > 20000 nM
Compound 4: only a limit was reported (the forecaster's own chance of this, stated with the estimate: 85%); the middle value does not contradict the limit.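

Compound 4 gives > 20000 nM in this assay, which is a limit of the assay and not a number. Among these compounds, no step from compound 1, compound 2 or compound 3 to compound 4 can be read. The compounds shown leave open at what concentration any of them reaches half-maximal cytotoxicity, and whether the group on the aromatic carbon alters it.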